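The source may report more compounds than this note shows. Statements on the series, on what has been measured and on what is new or still open speak of the compounds shown alone.

Measured compounds:
- compound 1 `CC(=O)OC[C@H]1O[C@@H](n2c(SCc3cc4ccccc4oc3=O)nc3cncnc32)[C@H](OC(C)=O)[C@@H]1OC(C)=O`: 39000 nM
- compound 2 `COc1cccc2cc(CSc3nc4cncnc4n3[C@@H]3O[C@H](COC(C)=O)[C@@H](OC(C)=O)[C@H]3OC(C)=O)c(=O)oc12`: 7500 nM
- compound 3 `O=c1oc2ccccc2cc1CSc1nc2cncnc2n1[C@@H]1O[C@H](CO)[C@@H](O)[C@H]1O`: 50000 nM

All three were tested in a functional assay on Huh-5-2 cells (Homo sapiens) for cytotoxicity, read by microscopy; on this read-out lower numbers stand for higher toxicity in this test and higher numbers for lower toxicity in this test. Compound 1 gives 39000 nM, compound 2 gives 7500 nM and compound 3 gives 50000 nM. Going by the values given here, the single change between compound 1 and compound 2 is methoxy in place of hydrogen on an aromatic carbon, and that change made a 5.2-fold lower number from compound 1 to compound 2 (0.72 log units; beyond the scatter). Compound 3 differs from compound 1 in more than one place; the difference between the two cores is not broken down here. Compound 4 `COc1cccc2cc(CSc3nc4cncnc4n3[C@@H]3O[C@H](CO)[C@@H](O)[C@H]3O)c(=O)oc12` is not yet measured in this assay. It arises from compound 3 by the same change, (methoxy in place of hydrogen on an aromatic carbon), at a place described in the same words. The step from compound 3 to compound 4 is expected to be a 4.5-fold lower number from compound 3 to compound 4 (0.66 log units; beyond the scatter) because the earlier step was a 5.2-fold lower number from compound 1 to compound 2 (0.72 log units; beyond the scatter). Compound 4 is estimated at 11000 nM, most likely between 4000 nM and 35000 nM.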

Compound 4, half-maximal cytotoxic concentration: 47000 nM
For compound 4 the middle estimate is 4.3-fold (0.63 log units) below the measured one; the whole stated range lies below it.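

In this assay, methoxy in place of hydrogen on an aromatic carbon gave a 1.1-fold lower number from compound 3 to compound 4 (0.03 log units; within the scatter), so the step seen on the core of compound 1 did not carry over to the core of compound 3. The two steps do not match: the same change on two cores in this assay, a 5.2-fold lower number (0.72 log units; beyond the scatter) from compound 1 to compound 2 and a 1.1-fold lower number (0.03 log units; within the scatter) from compound 3 to compound 4, 4.9-fold (0.69 log units) apart, beyond the scatter of two such steps. This shows that the same change need not give the same step on both cores in this series, but two pairs cannot show which difference between the cores matters, or what would happen on any other core.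

On these data alone, it remains open whether an amine or a chlorine atom at the same place would also give steps that differ between these two cores.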